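The source may report more compounds than this note shows. Statements on the series, on what has been measured and on what is new or still open speak of the compounds shown alone.

Compound 1 `Cc1ccc(-c2cc3cc(C#N)c(C#N)cc3n2O)cc1` and compound 2 `COc1ccc(-c2cc3cc(C#N)c(C#N)cc3n2O)cc1` share one core. In an assay on isolated protein for inhibition of Amine oxidase [flavin-containing] A (Homo sapiens), read by fluorescence and spectrophotometry, with a stated time of 20 min (on this read-out higher numbers stand for weaker inhibition and lower numbers for stronger inhibition), compound 1 gives 1140 nM and compound 2 gives 1840 nM. The change between them is methoxy in place of methyl on an aromatic carbon, and it made a 1.6-fold higher number from compound 1 to compound 2 (0.21 log units; within the scatter). Compound 3 `COn1c(-c2ccc(C)cc2)c(CO)c2cc(C#N)c(C#N)cc21` has a different core; the difference between the two cores is not broken down here. In this assay compound 3 gives 5120 nM, the highest of the three numbers, beyond the scatter from both compound 2 and compound 1. Compound 4 `COc1ccc(-c2c(CO)c3cc(C#N)c(C#N)cc3n2OC)cc1` is not yet measured. It differs from compound 3 by methoxy in place of methyl on an aromatic carbon, the same kind of change as that between compound 1 and compound 2; the description of the place in compound 3 adds the reading cut one bond further out. The step is expected to be a 1.6-fold higher number from compound 3 to compound 4 (0.19 log units; within the scatter), beside the earlier step, because a 1.6-fold higher number from compound 1 to compound 2 (0.21 log units; within the scatter) stayed within the scatter. Compound 4 is expected to give 8000 nM, between 4500 nM and 15000 nM.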

Compound 4, half-maximal inhibitory concentration: 1130 nM
Compound 4: middle estimate off by 7.1-fold (0.85 log units), on the high side, outside the stated range (below it).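

In this assay, methoxy in place of methyl on an aromatic carbon gives a 4.5-fold lower number from compound 3 to compound 4 (0.66 log units; beyond the scatter), so 4-methylphenyl to 4-methoxyphenyl cannot be carried from one core to the other in this series with its size and direction intact. Among these compounds, this rests on only two matched pairs and does not show which part of the difference between the cores goes with the different outcome, nor how the change would behave on any further core. The two steps do not agree: the same change on two cores in this assay, a 1.6-fold higher number (0.21 log units; within the scatter) from compound 1 to compound 2 and a 4.5-fold lower number (0.66 log units; beyond the scatter) from compound 3 to compound 4, 7.3-fold (0.86 log units) apart, beyond the scatter of two such steps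

Still open, on these data alone, is how other groups in the same place on the six-membered aromatic ring, such as an amine or a carboxylic acid, would read on each core. Also open, as far as these compounds go, is whether either step holds on a third core.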